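The source may report more compounds than this note shows. Statements on the series, on what has been measured and on what is new or still open speak of the compounds shown alone.

Working notes on the series.

Compound 1, `ClCc1ccc(Cn2cnc3c(Cl)ncnc32)cc1`, was tested in a functional assay on NCI-H522 cells (Homo sapiens) for cytotoxicity, read by sulforhodamine B assay, with a stated time of 48 h; a higher number here means that more compound is tolerated, a lower number that less compound is tolerated. In this assay compound 1 gives > 100000 nM, which is a limit of the assay and not a number. Compound 2, `ClCc1cccc(Cn2cnc3ncnc(Cl)c32)c1`, was tested in the same assay. In this assay compound 2 gives > 100000 nM, again a limit rather than a number. So compound 1 stands at the top of the numbers shown: both values sit at the same limit, as stated by the limit of > 100000 nM in this assay, at which 2 of the 2 values shown sit, and nothing in the measured pair separates the two compounds.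

Compound 3, `ClCc1ccc(Cn2cnc3c(Cl)nc(Cl)nc32)cc1`, has not yet been measured in this assay. It differs from compound 1 by chloro in place of hydrogen on an aromatic carbon; a chloro in place of hydrogen on an aromatic carbon. Going by the values given here, no step between measured compounds carries a comparable change, so there is no measured step to lean on. The expectation is that the step from compound 1 to compound 3 stays within the usual scatter or shows a modest move toward less tolerated concentrations, that is an at least 1.2-fold lower number from compound 1 to compound 3 (0.09 log units; that floor lies within the scatter). For compound 3 the estimate in this assay is 80000 nM, with a range from 20000 nM to 300000 nM, and a substantial chance that only a limit is reported again.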

Compound 3, concentration lethal to 50% of the cells: 97700 nM
Compound 3: middle estimate off by 1.2-fold (0.09 log units), on the low side; measured number inside the range.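

In this assay, going by these compounds alone, compound 3 gives 97700 nM, the only value shown so far that is a number, and it carries chloro in place of hydrogen on an aromatic carbon between two ring nitrogen atoms. Compound 1 gives > 100000 nM, which is a limit of the assay and not a number. The change can therefore be read only as an at least 1.0-fold lower number from compound 1 to compound 3 (0.01 log units; that floor lies within the scatter); this position now has a number on the chloro side, while the true distance between the two compounds stays unknown, with the hydrogen side still held at the limit: the limit of > 100000 nM in this assay, at which 2 of the 3 values shown sit.

The compounds shown leave open how an amine or a methoxy group at this same position would read in this assay, and whether either would give a number or a limit. They also leave open whether the same chloro in place of hydrogen would read alike on the core of compound 2, which so far offers only a limit.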